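The source may hold more compounds than are shown below. What is called first, only, known or untested is meant among the compounds shown, and "the series" means these compounds.

Measured so far in a functional assay on A549 cells (Homo sapiens) for antiproliferative activity, read by MTT assay, with a stated time of 72 h; on this read-out higher numbers stand for weaker inhibition and lower numbers for stronger inhibition:
compound 1, `CCCCCc1ccc(C#Cc2c(-c3ccc(CCCCC)cc3)oc3nc(=O)n(Cc4cn(-c5ccc(Cl)cc5)nn4)cc23)cc1`, gives > 100000 nM.
Compound 2, `CCCCCc1ccc(C#Cc2c(-c3ccc(CCCCC)cc3)oc3nc(=O)n(Cc4cn(Cc5ccccc5)nn4)cc23)cc1`, gives > 100000 nM.
Compound 3, `O=c1nc2oc(CCCCl)cc2cn1Cc1cn(Cc2ccccc2)nn1`, gives 27900 nM.

The value of compound 1 is a limit of the assay, not a number. The value of compound 2 is likewise a limit. Within the data shown here, compound 3 is the only member of the series with a number in this assay. Compound 1 differs from compound 2 by 4-chlorophenyl in place of benzyl on an aromatic nitrogen. The step that the two limits leave unreadable from compound 2 to compound 1 has no readable size because the limit of > 100000 nM in this assay, at which 2 of the 3 values shown sit, is where both of them sit.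

Compound 4, `O=c1nc2oc(CCCCl)cc2cn1Cc1cn(-c2ccc(Cl)cc2)nn1`, is not yet measured. Among the measured compounds shown here, it differs from compound 3 by 4-chlorophenyl in place of benzyl on an aromatic nitrogen, the same change as the one from compound 2 to compound 1, carried out on a different core; the difference between the two cores is not broken down here. The measured pair sets no size for this change, so the value of compound 3 is the only anchor. The expected step is a 1.1-fold lower number from compound 3 to compound 4 (0.05 log units; within the scatter), close to no change. Compound 4 is expected to give about 25000 nM in this assay, with a likely range from 8000 nM to 80000 nM.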

Compound 4, half-maximal inhibitory concentration: 52000 nM
Compound 4: the middle estimate sits 2.1-fold (0.32 log units) below what was measured, and the stated range covers the measured number.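

In this assay, 4-chlorophenyl in place of benzyl on an aromatic nitrogen gives a 1.9-fold higher number from compound 3 to compound 4 (0.27 log units; within the scatter), so on the core of compound 3 this change does not separate the two compounds. On the core of compound 2 the size of the same change cannot be read, because compound 1 and compound 2 both stand at a limit of the assay rather than at a number: the limit of > 100000 nM in this assay, at which 2 of the 4 values shown sit. The series therefore offers a single readable instance of this change, and that instance shows neither that its size carries from one core to the other nor that it fails to carry.

Open, as far as these compounds go, is how this assay would respond to an amine, a carboxylic acid or a longer chain in place of the chlorine-bearing chain shared by compound 3 and compound 4. Also open, from the compounds shown here alone, is whether any compound on the core of compound 1 would give a number rather than a limit, which a readable comparison between the two cores would need.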